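This account rests on a few compounds, and the source may have more. Where it says the series, first, only, none or still open, it means among the compounds named here.

Compound 1 `COc1ccc(NC(=O)[C@@H]2CC=C(CCC=C(C)C)C[C@H]2c2ccccc2)cc1`: > 23000 nM
Compound 2 `CC(C)=CCCC1=CC[C@@H](C(=O)Nc2ccc(C(=O)O)cc2)[C@H](c2ccccc2)C1`: 2200 nM

In an assay on isolated protein for inhibition of Apoptosis regulator Bcl-2 (Homo sapiens), read by fluorescence polarization, with stated times of 5 min and 10 min (on this read-out lower numbers stand for stronger inhibition and higher numbers for weaker inhibition), compound 2 gives 2200 nM, the only number shown. Compound 1 gives > 23000 nM, which is a limit of the assay rather than a number (the limit of > 23000 nM in this assay, at which 1 of the 2 values shown sits). For the measured compounds named here, the one measured step, an at least 10-fold lower number from compound 1 to compound 2 (1.01 log units; beyond the scatter), came with the carboxy entering. Compound 3 `CC(C)=CCCC1=CC[C@@H](C(=O)NO)[C@H](c2ccccc2)C1` differs from compound 2 by hydroxy in place of 4-carboxyphenyl on an amide-type nitrogen, so the whole 4-carboxyphenyl that carried that carboxy leaves. Given an at least 10-fold lower number from compound 1 to compound 2 (1.01 log units; beyond the scatter), a large move toward weaker inhibition is expected, a 6.8-fold higher number from compound 2 to compound 3 (0.83 log units; beyond the scatter). Compound 3 is therefore estimated at 15000 nM, between 3000 nM and 60000 nM, and may well be reported only as a limit.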

Compound 3, inhibition constant: 700 nM
Compound 3: the middle estimate sits 21-fold (1.33 log units) above what was measured; the whole stated range lies above it.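

The whole 4-carboxyphenyl on the amide-type nitrogen is not needed for inhibition here: with hydroxy in its place the result is a 3.1-fold lower number from compound 2 to compound 3 (0.50 log units; beyond the scatter), so one heavy atom does better than the nine that left. Against the 4-methoxyphenyl, the same hydroxy gives an at least 32-fold lower number from compound 1 to compound 3 (1.51 log units; beyond the scatter). That step starts from compound 1, which stands at a limit and not at a number: the limit of > 23000 nM in this assay, at which 1 of the 3 values shown sits.

Going by these compounds, whether the hydroxy itself contributes or the gain comes only from losing the aromatic ring stays open. A plain amide hydrogen, a methoxy or a carboxymethyl on that nitrogen would separate the two.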